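The source may report more compounds than this note shows. Statements on the series, on what has been measured and on what is new or still open speak of the compounds shown alone.

Compound 1 `CC#C[C@@H](CC(=O)O)c1ccc(OC[C@H]2COc3ccc(Cl)cc3O2)cc1` gives 86% in a functional assay on HEK293 cells for agonist activity at Free fatty acid receptor 1 (Homo sapiens), read by fluorescence and calcium flux, with a stated time of 10 min (a lower number here means a smaller maximal response, a higher number a larger maximal response), the highest of the three numbers measured. Its mirror image, compound 2 `CC#C[C@H](CC(=O)O)c1ccc(OC[C@@H]2COc3ccc(Cl)cc3O2)cc1`, gives 41%. Compound 3 `CC#C[C@@H](CC(=O)O)c1ccc(OC[C@@H]2COc3ccc(Cl)cc3O2)cc1` differs from compound 1 only in configuration as drawn, and in this assay compound 3 gives 65%. The measured steps are a number 45 percentage points lower from compound 1 to compound 2 (beyond the scatter), a number 21 percentage points lower from compound 1 to compound 3 (beyond the scatter) and a number 24 percentage points higher from compound 2 to compound 3 (beyond the scatter), and each of them is a change of configuration alone the fact that compounds 1 and 2 differ only in the configuration as drawn the fact that compounds 1 and 3 differ only in the configuration as drawn (the fact that compounds 2 and 3 differ only in the configuration as drawn). Compound 4 `CC#C[C@@H](CC(=O)O)c1ccc(OC[C@H]2COc3ccc(S(C)(=O)=O)cc3O2)cc1` differs from compound 1 in a different way: methylsulfonyl in place of chloro on an aromatic carbon. Within the data shown here, none of the measured steps exchanges one group for another, so none bears directly on this change, and the data give no basis for a shift beyond the scatter in this assay. Compound 4 is therefore expected to give about 80%, within a range from 55% to 100%, which would be a step of a number 6 percentage points lower from compound 1 to compound 4 (within the scatter).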

Compound 4, largest response reached (Emax), in percent of the reference or control that the assay uses: 55%
The estimate for compound 4 lay 25 percentage points above the measured number; low and high end bracket the measured number.
By their numbers in this assay, from the lowest: compound 2; then compounds 4 and 3 (each within the scatter of the next); then compound 1.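

In this assay, methylsulfonyl in place of chloro on this aromatic carbon gives a number 31 percentage points lower from compound 1 to compound 4 (beyond the scatter). Among these compounds, the group at this position of the shared core therefore matters to the largest response reached, as the configuration did in the earlier compounds. Nothing given here accounts for this shift.

Going by these compounds, whether a nitrile, a methoxy group or fluoro at this position would hold the response of compound 1 remains open. On these data alone, it is also open whether methylsulfonyl would lower the response to the same extent in the configuration of compound 3.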